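Swapping one chloro for fluoro on a doubly substituted pyrazole pair

The source may report more compounds than this note shows. Statements on the series, on what has been measured and on what is new or still open speak of the compounds shown alone.

Of the compounds shown here, three that share one core have been measured in an assay on mitochondria from brain for inhibition of Amine oxidase [flavin-containing] A (Bos taurus), read by fluorescence; a lower number here means a stronger inhibitor, a higher number a weaker inhibitor. Compound 1 `Clc1ccc(-c2cc(-c3ccccc3)n[nH]2)cc1` gives 302 nM. Compound 2 `Fc1ccc(-c2cc(-c3ccccc3)n[nH]2)cc1` gives 4070 nM. Compound 3 `Clc1ccc(-c2cc(-c3ccc(Cl)cc3)[nH]n2)cc1` gives 2.04 nM, the lowest number of the three, so compound 3 is the strongest inhibitor among them. The two measured steps are both large: a 150-fold lower number from compound 1 to compound 3 (2.17 log units; beyond the scatter), and a 13-fold higher number from compound 1 to compound 2 (1.13 log units; beyond the scatter).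

Compound 4 `Fc1ccc(-c2cc(-c3ccc(Cl)cc3)n[nH]2)cc1` has not yet been measured. It differs from compound 3 in one place: fluoro in place of chloro on an aromatic carbon. For the measured compounds named here, the step that bears on this change is the one from compound 1 to compound 2, where the same exchange of chloro for fluoro gave a 13-fold higher number from compound 1 to compound 2 (1.13 log units; beyond the scatter). A step of similar size in the same direction, toward a weaker inhibitor, is therefore expected in this assay, namely a 12-fold higher number from compound 3 to compound 4 (1.09 log units; beyond the scatter). On that basis compound 4 is estimated to give 25 nM, with a plausible range from 8 nM to 80 nM.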

Compound 4, half-maximal inhibitory concentration: 3.02 nM
Beside the measured number, compound 4's estimate is 8.3-fold (0.92 log units) above it, and the stated range ends above it.
By their numbers in this assay, from the lowest: compounds 3 and 4 (each within the scatter of the next); then compound 1; then compound 2.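

The exchange of chloro for fluoro, para to a large group, does not have a fixed size in this assay, for on the core of compound 3 it gives a 1.5-fold higher number from compound 3 to compound 4 (0.17 log units; within the scatter). What it does depends on what the rest of the molecule carries: the same change on two cores in this assay, a 13-fold higher number (1.13 log units; beyond the scatter) from compound 1 to compound 2 and a 1.5-fold higher number (0.17 log units; within the scatter) from compound 3 to compound 4, 9.1-fold (0.96 log units) apart, beyond the scatter of two such steps The same holds when the four compounds are read the other way, since chloro in place of hydrogen gives a 1300-fold lower number from compound 2 to compound 4 (3.13 log units; beyond the scatter), and the size of that step also differs between the two cores: the same change on two cores in this assay, a 150-fold lower number (2.17 log units; beyond the scatter) from compound 1 to compound 3 and a 1300-fold lower number (3.13 log units; beyond the scatter) from compound 2 to compound 4, 9.1-fold (0.96 log units) apart, beyond the scatter of two such steps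

The compounds shown leave open whether a bromo, a methoxy or an amine at this position would match compound 3 or fall back toward compound 2. Four compounds also cannot tell whether this dependence on the rest of the molecule extends beyond the shared core.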